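Branching the butyl chain of compound 2

The source may hold more compounds than are shown below. What is called first, only, known or untested is meant among the compounds shown, and "the series" means these compounds.

The shared core carries a benzyl-substituted pyrazole and a chain on one ring nitrogen. Compound 1 `CCCn1c(=O)[nH]c(=O)c2[nH]c(-c3cnn(Cc4ccccc4)c3)nc21` bears a propyl chain there, and compound 2 `CCCCn1c(=O)[nH]c(=O)c2[nH]c(-c3cnn(Cc4ccccc4)c3)nc21` a butyl chain. In an assay on HEK293 cells for displacement of a labelled ligand from adenosine receptor A2b (Homo sapiens) (on this read-out higher numbers stand for weaker inhibition and lower numbers for stronger inhibition), compound 1 reaches only the limit > 6000 nM. Compound 2 likewise stops at the limit > 6000 nM in this assay. The step from compound 1 to compound 2 is a step that the two limits leave unreadable from compound 1 to compound 2, and the limit of > 6000 nM in this assay, at which 2 of the 2 values shown sit, is all the record of this series offers: both values sit at the limit, so the size of any chain-lengthening effect is not readable. Compound 2 therefore stands only as a limit, not as a number, and the other value shown is a limit too. Compound 3 `CC(C)Cn1c(=O)[nH]c(=O)c2[nH]c(-c3cnn(Cc4ccccc4)c3)nc21` differs from compound 2 by isopropyl in place of propyl on a saturated chain carbon bound to an aromatic nitrogen. Among the compounds with values here, no measured step bears directly on this branching; the one step available was unreadable. The step that the limit leaves unreadable from compound 2 to compound 3 is thus estimated as none beyond the scatter, and the outcome most likely remains a limit. For compound 3 the estimate in this assay is 12000 nM, with a range from 4000 nM to 40000 nM.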

Compound 3, inhibition constant: > 6000 nM
Compound 3: only a limit was reported (the forecaster's own chance of this, stated with the estimate: 80%); the middle value does not contradict the limit.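

In this assay compound 3 gives only the limit > 6000 nM. Within the data shown here, its steps from compound 1 and from compound 2 therefore cannot be read, and this result yields no new step. The compounds shown leave open how far, if at all, the propyl, butyl and isobutyl chains differ on the shared core: the limit of > 6000 nM in this assay, at which 3 of the 3 values shown sit.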